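Working notes: cyano to methyl exchange on the aryl substituent

The compounds below may be only part of what the source reports. "The series", "measured", "known", "first", "only" and "open" are said of these compounds alone.

Measured so far:
compound 1 `c1ccc(-c2ccc3cccnc3n2)cc1` — 1840 nM
compound 2 `N#Cc1cccc(-c2ccc3cccnc3n2)c1` — 115 nM

In a functional assay on CHO cells for antagonist activity at metabotropic glutamate receptor 5 (Rattus norvegicus), read by calcium flux (on this read-out higher numbers stand for weaker inhibition and lower numbers for stronger inhibition), compound 1 gives 1840 nM and compound 2 gives 115 nM. Within the data shown here, the only measured step, a 16-fold lower number from compound 1 to compound 2 (1.20 log units; beyond the scatter), is the one in which cyano entered in place of hydrogen; it leaves compound 2 with the lowest of the two numbers, compound 1 being its nearest neighbour.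

Compound 3 `Cc1cccc(-c2ccc3cccnc3n2)c1` is not yet measured. Its change from compound 2 is methyl in place of cyano on an aromatic carbon. The step that bears on it is a 16-fold lower number from compound 1 to compound 2 (1.20 log units; beyond the scatter), which was large, and compound 3 gives up exactly the cyano that entered in that step. Nothing is known here about methyl against hydrogen at this position. The gain seen with cyano is therefore expected to be returned at least in part, and compound 3 is expected to land between the numbers of compound 1 and compound 2. The expected step is a 6.1-fold higher number from compound 2 to compound 3 (0.78 log units; beyond the scatter). The estimate for compound 3 is 700 nM, with a range from 200 nM to 2500 nM.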

Compound 3, half-maximal inhibitory concentration: 225 nM
The estimate for compound 3 lay 3.1-fold (0.49 log units) above the measured number; measured number inside the range.
By their numbers in this assay, from the lowest: compounds 2 and 3 (each within the scatter of the next); then compound 1.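

In this assay the exchange gives a 2.0-fold higher number from compound 2 to compound 3 (0.29 log units; within the scatter) and so does not separate methyl from cyano at this position. Methyl in place of hydrogen gives an 8.2-fold lower number from compound 1 to compound 3 (0.91 log units; beyond the scatter) on the same aromatic carbon, which shows that the lower number seen with cyano does not depend on the nitrile: methyl brings no triple bond and no hydrogen-bond acceptor, yet it also stands beyond the scatter from compound 1. No measurement at hand accounts for the effect of either group.

On these data alone, whether other substituents at this position would keep the lower number stays open, for example a chlorine atom, a methoxy group, an amine or a longer chain such as ethyl. Also open, as far as these compounds go, is whether methyl and cyano would still match on other carbons of this ring.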